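Oxy in place of amino on the oxan-4-yl side chain

The source may report more compounds than this note shows. Statements on the series, on what has been measured and on what is new or still open speak of the compounds shown alone.

In a physicochemical assay for permeability, using PAMPA, with a stated time of 3 h, at pH 7.4 (on this read-out higher numbers stand for higher permeability and lower numbers for lower permeability), compound 1 `O=C(O)CCNc1cc(Nc2ccc3[nH]c(=O)[nH]c3c2)c(Cl)cc1[N+](=O)[O-]` is reported as "impermeable" (no number reported) with no number attached. Among the compounds with values here, compound 2 `O=c1[nH]c2ccc(Nc3cc(NC4CCOCC4)c([N+](=O)[O-])cc3Cl)cc2[nH]1` gives 101 nm/s and is therefore the only compound with a numerical reading so far. Compound 3 `O=c1[nH]c2ccc(Nc3cc(OC4CCOCC4)c([N+](=O)[O-])cc3Cl)cc2[nH]1` differs from compound 2 at one place (oxan-4-yl)oxy in place of (oxan-4-yl)amino on an aromatic carbon with (oxan-4-yl)oxy in place of (oxan-4-yl)amino on an aromatic carbon, ortho to a nitro group and para to a chloro group. Within the data shown here, no measured pair shows the size of this exchange in this assay and the estimate has only one numerical anchor. A modest upward move is expected, estimated as a 1.6-fold higher number from compound 2 to compound 3 (0.20 log units; within the scatter) and not clearly beyond the usual scatter. In this assay compound 3 is expected at 160 nm/s with an estimated range from 60 nm/s to 400 nm/s for the measurement.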

Compound 3, apparent permeability: 45 nm/s
Estimate against measurement, compound 3: 3.6-fold (0.55 log units) above, outside the stated range (below it).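

Placing (oxan-4-yl)oxy in place of (oxan-4-yl)amino, ortho to a nitro group and para to a chloro group, gives a 2.2-fold lower number from compound 2 to compound 3 (0.35 log units; beyond the scatter) in this assay and provides the first measured step at this position. The two side chains match in heavy atoms and hydrogen-bond acceptors, and the entering group has no hydrogen-bond donor where the leaving group has one, so this modest step is tied to a small structural exchange. No measurement shown here accounts for the direction of the step.

Going by these compounds, whether the same exchange gives a step of this size with a side chain other than oxan-4-yl remains open. Also open, on these data alone, is how a thioether link or a tertiary amine link carrying a methyl group would read at this position in this assay.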